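This account rests on a few compounds, and the source may have more. Where it says the series, first, only, none or still open, it means among the compounds named here.

Compound 1 `CC1CN=C(c2ccc(-c3noc(-c4ccc(Cl)c(Cl)c4)n3)cc2)N1`: 160 nM
Compound 2 `Clc1cccc(-c2nc(-c3cccc(C4=NCCN4)c3)no2)c1`: 30 nM
Compound 3 `CC(C)c1noc(-c2ccc(C3=NCCN3)cc2)n1`: 230 nM

In an assay for inhibition of Amine oxidase [flavin-containing] B (Homo sapiens), read by fluorescence and spectrophotometry, using microsomes, with stated times of 30 min and 20 min (on this read-out lower numbers stand for stronger inhibition and higher numbers for weaker inhibition), compound 3 gives the highest of the three numbers. Compound 1 sits within the scatter of compound 3, whereas compound 2 lies well beyond it with a much lower number. Compound 4 `Cc1ccc(Cc2noc(-c3ccc(C4=NCCN4)cc3)n2)cc1` differs from compound 3 by 4-methylbenzyl in place of isopropyl on an aromatic carbon. Among the measured compounds shown here, no measured pair isolates this exact change, so the size of the step cannot be read directly from the measurements. Compound 2 also carries an aromatic ring at this position and gives 30 nM, which suggests the step from compound 3 to compound 4 is expected to run downward, a 2.1-fold lower number from compound 3 to compound 4 (0.32 log units; beyond the scatter), though modestly. Compound 4 is therefore estimated at 110 nM, with a range from 35 nM to 350 nM.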

Compound 4, half-maximal inhibitory concentration: 3640 nM
For compound 4 the middle estimate is 33-fold (1.52 log units) below the measured one, and the stated range ends below it.
By their numbers in this assay, from the lowest: compound 2; then compounds 1 and 3 (each within the scatter of the next); then compound 4.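

In this assay, 4-methylbenzyl in place of isopropyl on this aromatic carbon, between two ring nitrogen atoms, gives a 16-fold higher number from compound 3 to compound 4 (1.20 log units; beyond the scatter). Among the compounds shown here, this is the first step that isolates a single change, and it shows that at this position the larger group with its six-membered aromatic ring goes with clearly weaker inhibition. Nothing available explains this step. The compounds shown leave open whether the added ring or the para-free chain length matters more: an unsubstituted benzyl, a plain phenyl or a methyl here remains unknown.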